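Larger Aryl Group at the Alcohol Carbon

This account rests on a few compounds, and the source may have more. Where it says the series, first, only, none or still open, it means among the compounds named here.

Three compounds have so far been examined in an ADME assay on RAW264.7 cells (Mus musculus) for cytotoxicity, read by MTT assay, with a stated time of 24 h, in the absence of a further agent; on this read-out lower numbers stand for stronger inhibition and higher numbers for weaker inhibition. Compound 1 `O=C1OC(Cc2nc(-c3ccccc3)no2)c2ccccc21` and compound 2 `O=C1OC(Cc2nc(-c3ccc(-c4ccccc4)cc3)no2)c2ccccc21` share one core, while compound 3 `COCCOc1ccc(C(O)C2OC(=O)c3c(OC)cc(OC)cc32)cc1` is built on a different core. In this assay compound 1 gives > 40000 nM, which is a limit of the assay rather than a number. Compound 2 gives > 40000 nM, again only a limit. The step that the two limits leave unreadable from compound 1 to compound 2 therefore cannot be read. Compound 3 gives > 40000 nM, once more a limit. All three thus sit at the same point: the limit of > 40000 nM in this assay, at which 3 of the 3 values shown sit. Compound 4 `COc1cc(OC)c2c(c1)C(C(O)c1ccc(OCc3ccc(OC(F)(F)F)cc3)cc1)OC2=O` has not yet been measured; it differs from compound 3 in one place, (4-(trifluoromethoxy)phenyl in place of methoxymethyl on a saturated chain carbon bound to an oxygen on an aromatic ring). Within the data shown here, no measured step bears on this change, and the single known step is itself unreadable, so no shift beyond the scatter can be expected in either direction. The step that the limit leaves unreadable from compound 3 to compound 4 is therefore expected to be flat, with compound 4 estimated at 45000 nM within a range from 15000 nM to 150000 nM, most likely again reported only as a limit.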

Compound 4, half-maximal inhibitory concentration: > 40000 nM
Compound 4: no number, only a limit; the forecaster's own chance of this, stated with the estimate: 75%; the middle value does not contradict the limit.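

Compound 3 and compound 4 cannot be compared by size, and neither can compound 1 and compound 2, because each result is only a limit: the limit of > 40000 nM in this assay, at which 4 of the 4 values shown sit. Going by these compounds, whether any of these four compounds differs from another in this assay remains open.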